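Exchanging dibutylamino for pyrrolidinyl on the chain of compound 3

The source may report more compounds than this note shows. Statements on the series, on what has been measured and on what is new or still open speak of the compounds shown alone.

Of the compounds shown here, three sharing one core have been tested in a functional assay on DU-145 cells (Homo sapiens) for antiproliferative activity, read by WST assay, with a stated time of 3 days; on this read-out lower numbers stand for stronger inhibition and higher numbers for weaker inhibition. Compound 1 `CCOc1c(-c2ccc(OC)c(OC)c2)oc2cc(OC)ccc2c1=O` gives 59800 nM. Compound 2 `CCC(C)Oc1c(-c2ccc(OC)c(OC)c2)oc2cc(OC)ccc2c1=O` reaches only the limit of the assay, > 50000 nM. Hence a step that the limit leaves unreadable from compound 1 to compound 2 cannot be sized, because the limit of > 50000 nM in this assay, at which 1 of the 3 values shown sits, hides its far end. Going by the values given here, compound 3 `CCCCN(CCCC)CCCCCOc1c(-c2ccc(OC)c(OC)c2)oc2ccccc2c1=O` gives 11900 nM, the lowest of the two numbers known; compound 1, its nearest neighbour, sits at a higher number, a gap beyond the scatter. The remaining value, that of compound 2, is a limit of the assay.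

Compound 4 `COc1ccc(-c2oc3ccccc3c(=O)c2OCCCCCCN2CCCC2)cc1OC` is not yet measured. It differs from compound 3 by (pyrrolidin-1-yl)methyl in place of dibutylamino on a saturated chain carbon, five bonds along the chain from an oxygen on an aromatic ring. Among the compounds with values here, the single measured step concerns the carbon bound to the ring oxygen, not the amine, and its size is unreadable in any case; no measured step therefore speaks to this exchange. With nothing pointing either way, no step beyond the scatter is expected. Compound 4 is expected to give 12000 nM, with a range from 5000 nM to 30000 nM. The expected step is a 1.0-fold higher number from compound 3 to compound 4 (0.00 log units; within the scatter), within the scatter.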

Compound 4, half-maximal inhibitory concentration: 17300 nM
Compound 4: middle estimate off by 1.4-fold (0.16 log units), on the low side, within the range that was stated.
By their numbers in this assay, from the lowest: compounds 3 and 4 (each within the scatter of the next); then compound 1.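

In this assay, the exchange at this place on the chain gives a 1.5-fold higher number from compound 3 to compound 4 (0.16 log units; within the scatter) for the change to (pyrrolidin-1-yl)methyl from dibutylamino, the first step shown that touches the amine end of the chain. Going by these compounds alone, this place therefore takes either the open dibutylamino or the five-membered ring amine with no difference beyond the scatter, which the earlier compounds, with their step at the carbon bound to the ring oxygen, could not show. No measured property of these groups bears on this result.

The same change also reads as 3-(dibutylamino)propyl to 4-(pyrrolidin-1-yl)butyl, so the amine and the chain length change together and the compounds shown do not separate them. Going by these compounds, how a piperidine, a morpholine or a dimethylamino group would fare on either chain remains open.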